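Benzothiazole amide series: swapping the aryl amide group

A few compounds are considered here, and "the series" means these few. Any claim that something is new, unique, unknown or untested is made for them only; others in the source may bear on it.

Compound 1 `O=C(CSc1nc2ccc(NC(=O)c3ccc(Cl)cc3)cc2s1)NCc1ccc(Cl)cc1` carries a (4-chlorophenyl)carbonyl amide on the shared core and, in a functional assay on MCF7 cells (Homo sapiens) for cytotoxicity, read by MTT assay, with a stated time of 48 h (a higher number here means a weaker inhibitor, a lower number a stronger inhibitor), compound 1 gives 29300 nM. Among the measured compounds shown here, of the two numbers in hand it stands highest, though only by a margin that means nothing: the related compound 2 `O=C(CSc1nc2ccc(NC(=O)c3ccc(Cl)cc3)cc2s1)NCc1ccccc1` gives in this assay 25900 nM, and the single measured step, a 1.1-fold lower number from compound 1 to compound 2 (0.05 log units; within the scatter), tells that removing the chloro from the benzyl end leaves the reading unchanged.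

Compound 3 `COc1ccccc1C(=O)Nc1ccc2nc(SCC(=O)NCc3ccc(Cl)cc3)sc2c1` keeps the chloro-bearing benzyl amide of compound 1 and changes the other end: 2-methoxyphenyl in place of 4-chlorophenyl on a carbonyl carbon. For the measured compounds named here, no measured step touches this amide-side aryl group, so the only guide is the general insensitivity seen at the far end, where compound 1 and compound 2 sit together within the scatter. The expectation for this assay is therefore a step of no size beyond the scatter, a 1.1-fold lower number from compound 1 to compound 3 (0.05 log units; within the scatter), in no preferred direction. Compound 3 is estimated at 26000 nM in this assay, with a range from 10000 nM to 70000 nM.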

Compound 3, half-maximal inhibitory concentration: 1100 nM
Beside the measured number, compound 3's estimate is 24-fold (1.37 log units) above it, outside the stated range (below it).
By their numbers in this assay, from the lowest: compound 3; then compounds 2 and 1 (each within the scatter of the next).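

Among the compounds shown here, the amide-side aryl group is a position that answers in this assay: 2-methoxyphenyl in place of 4-chlorophenyl on a carbonyl carbon gives a 27-fold lower number from compound 1 to compound 3 (1.43 log units; beyond the scatter), while the one earlier step, at the benzyl end, gave a 1.1-fold lower number from compound 1 to compound 2 (0.05 log units; within the scatter) and stayed within the scatter. The flatness seen at the benzyl end therefore does not extend to the other end of the molecule, and among these three compounds the aryl group on the amide carbonyl is the only place where a change has moved the reading beyond the scatter. No measurement available here bears on the reason for a step of this size.

This one step removes the 4-chlorophenyl group and brings in the 2-methoxyphenyl group together, so the compounds shown do not separate loss of the chloro from gain of the methoxy; plain phenyl, 2-chlorophenyl and 4-methoxyphenyl on the same carbonyl carbon would divide the two. Also open, going by these compounds, is whether the benzyl-end chloro stays without effect once 2-methoxyphenyl is in place, and how an amine or a carboxylic acid on this aryl group would read.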